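The source may report more compounds than this note shows. Statements on the series, on what has been measured and on what is new or still open speak of the compounds shown alone.

Working notes on the series. Compound 1 `CCn1c(C(=O)NCC(=O)OC)ccc1C(CC)(CC)c1ccc(OCS(=O)(=O)c2ccccc2)c(C)c1` carries a methoxycarbonyl on the amide side chain; in a functional assay on MCF7 cells (Homo sapiens) for antiproliferative activity, read by MTT assay, with a stated time of 24 h (on this read-out lower numbers stand for stronger inhibition and higher numbers for weaker inhibition), compound 1 reaches only a limit of the assay, > 50000 nM. Compound 2 `CCn1c(C(=O)NCCO)ccc1C(CC)(CC)c1ccc(OCS(=O)(=O)c2ccccc2)c(C)c1` gives 15500 nM and compound 3 `CCn1c(C(=O)NC2(CO)CC2)ccc1C(CC)(CC)c1ccc(OCS(=O)(=O)c2ccccc2)c(C)c1` gives 28800 nM. The step of an at least 3.2-fold lower number from compound 1 to compound 2 (0.50 log units; beyond the scatter) is the one clear movement; an at least 1.7-fold lower number from compound 1 to compound 3 (0.23 log units; that floor lies within the scatter) and a 1.9-fold higher number from compound 2 to compound 3 (0.27 log units; within the scatter) both sit within the scatter, so compound 3 holds the higher of the two numbers without being separable from compound 2. Compound 4 `CCn1c(C(=O)NCC(=O)O)ccc1C(CC)(CC)c1ccc(OCS(=O)(=O)c2ccccc2)c(C)c1` differs from compound 3 by carboxymethyl in place of 1-(hydroxymethyl)cyclopropyl on an amide-type nitrogen and so returns to the open chain of compound 1 with a carboxymethyl in place of its methoxycarbonyl. Within the data shown here, no measured step covers that acid; the weak numbers of compound 1 and compound 3 suggest no gain. Compound 4 is expected at 40000 nM (range 15000 nM to 100000 nM), a step of a 1.4-fold higher number from compound 3 to compound 4 (0.14 log units; within the scatter), with a fair chance of a limit only.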

Compound 4, half-maximal inhibitory concentration: 33100 nM
Beside the measured number, compound 4's estimate is 1.2-fold (0.08 log units) above it; the measured number falls inside the stated range.
By their numbers in this assay, from the lowest: compounds 2, 3 and 4 (each within the scatter of the next, the first and the last beyond it). At a limit, above all of these: compound 1.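

On the open chain, carboxy in place of hydroxymethyl gives a modest step, a 2.1-fold higher number from compound 2 to compound 4 (0.33 log units; beyond the scatter), so the end group of the chain on this amide-type nitrogen does register in this assay. Carboxymethyl in place of 1-(hydroxymethyl)cyclopropyl does not separate the two compounds: a 1.1-fold higher number from compound 3 to compound 4 (0.06 log units; within the scatter). Hydrogen in place of methyl on an oxygen next to a carbonyl group gives an at least 1.5-fold lower number from compound 1 to compound 4 (0.17 log units; that floor lies within the scatter), which rests on a limit of the assay and cannot be read as a change: the limit of > 50000 nM in this assay, at which 1 of the 4 values shown sits.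

On these data alone, whether a primary amine or a longer chain ending in hydroxyl on this nitrogen would reach a lower number than compound 2 stays open.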